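The source may hold more compounds than are shown below. What is called first, only, known or untested is meant among the compounds shown, and "the series" means these compounds.

Measured in an ADME assay on HeLa cells (Homo sapiens) for cytotoxicity, read by resazurin assay, with a stated time of 2 days; on this read-out lower numbers stand for stronger inhibition and higher numbers for weaker inhibition:
- Compound 1 `Cn1c([N+](=O)[O-])cnc1/C=C/c1ccccc1`: > 100000 nM
- Compound 2 `Cn1c([N+](=O)[O-])cnc1/C=C/c1ccc(Br)cc1`: 72400 nM
- Compound 3 `Cn1c([N+](=O)[O-])cnc1/C=C/c1ccc(Cl)cc1`: 91200 nM

Compound 1 stands at the limit of > 100000 nM in this assay, at which 1 of the 3 values shown sits. That entry is a limit and not a number.

Compound 4 `COc1cccc(/C=C/c2ncc([N+](=O)[O-])n2C)c1` changes compound 1 in one place, with methoxy in place of hydrogen on an aromatic carbon. Among the compounds with values here, no methoxy compound has been measured, so the closest guides are two other replacements of hydrogen on an aromatic carbon. These are an at least 1.3-fold lower number from compound 1 to compound 2 (0.14 log units; that floor lies within the scatter) and an at least 1.0-fold lower number from compound 1 to compound 3 (0.04 log units; that floor lies within the scatter). The two halogens also compare closely, with a 1.3-fold higher number from compound 2 to compound 3 (0.10 log units; within the scatter). A step beyond the scatter is therefore not expected, and the expected step is an at least 1.1-fold lower number from compound 1 to compound 4 (0.04 log units; that floor lies within the scatter). The estimated value for compound 4 is 90000 nM, within an expected range of 50000 nM to 160000 nM.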

Compound 4, half-maximal inhibitory concentration: > 100000 nM
Compound 4 gave a limit, no number; the forecaster's own chance of this, stated with the estimate: 40%; middle value at least 1.1-fold (0.04 log units) from the limit.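

Within the data shown here, compound 1 and compound 4 each give a limit rather than a number, so no step between them can be read: the limit of > 100000 nM in this assay, at which 2 of the 4 values shown sit. From the compounds shown here alone, whether methoxy in place of hydrogen on an aromatic carbon changes the number at all stays open.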